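Cyclohexyl at the Ring Carbon Opposite the Nitrogen

The source may hold more compounds than are shown below. What is called first, only, known or untested is meant among the compounds shown, and "the series" means these compounds.

Measured compounds:
- compound 1, `[O-][n+]1cccc(Oc2ccccc2)c1`: 100 mg/kg
- compound 2, `Cc1cc[n+]([O-])cc1Oc1ccccc1`: 30 mg/kg
- compound 3, `CC(C)(C)c1cc[n+]([O-])cc1Oc1ccccc1`: 30 mg/kg

Of the compounds shown here, three sharing one core have been tested in a functional assay on the whole organism with Mus musculus as the target, in the maximal electroshock model, with a stated time of 30 min; a higher number here means that more compound is needed for the effect, a lower number that less compound is needed. Compound 1 stands highest of the three; compound 2 and compound 3 both sit lower, as the steps of a 3.3-fold lower number from compound 1 to compound 2 (0.52 log units; beyond the scatter) and a 3.3-fold lower number from compound 1 to compound 3 (0.52 log units; beyond the scatter) show, each beyond the scatter. Between compound 2 and compound 3 the step is no change at the digits printed from compound 2 to compound 3 (within the scatter), within the scatter.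

The next compound, compound 4, `[O-][n+]1ccc(C2CCCCC2)c(Oc2ccccc2)c1`, has not yet been tested in this assay. It differs from compound 1 by cyclohexyl in place of hydrogen on an aromatic carbon. The group enters at the same aromatic carbon where methyl and tert-butyl entered in compound 2 and compound 3, so the two steps from compound 1 bear directly on it, and the step from methyl to tert-butyl suggests that enlarging the group there made no further difference. A lowering of similar size is therefore expected for compound 4, estimated as a 3.3-fold lower number from compound 1 to compound 4 (0.52 log units; beyond the scatter), giving an expected value of 30 mg/kg, within the range 10 mg/kg to 100 mg/kg.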

Compound 4, minimum effective dose: > 300 mg/kg
Compound 4 ended at the assay's limit; the forecaster's own chance of this, stated with the estimate: 10%; middle value at least 10-fold (1.00 log units) away from the limit.
By their numbers in this assay, from the lowest: compounds 2 and 3 (each within the scatter of the next); then compound 1. At a limit, above all of these: compound 4.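

At this aromatic carbon, opposite the ring nitrogen, a carbon group does not always lower the number in this assay: cyclohexyl reverses the direction of the change, with an at least 3.0-fold higher number from compound 1 to compound 4 (0.47 log units; beyond the scatter). Methyl and tert-butyl could not be told apart here, yet cyclohexyl separates sharply from both, with an at least 10-fold higher number from compound 3 to compound 4 (1.00 log units; beyond the scatter) and an at least 10-fold higher number from compound 2 to compound 4 (1.00 log units; beyond the scatter), so the flat step seen earlier does not extend to every larger group. All three steps rest on a limit of the assay and not on a number: the limit of > 300 mg/kg in this assay, at which 1 of the 4 values shown sits.

The compounds shown leave open whether the reversal belongs to the six-membered ring of cyclohexyl or would also appear with cyclopropyl or a longer chain. They also leave open how an amine or a carboxylic acid at this carbon would behave.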